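Replacing Allyl on a Compound at the Assay Limit

This account rests on a few compounds, and the source may have more. Where it says the series, first, only, none or still open, it means among the compounds named here.

Compound 1 (`C=CCC(O)(c1ccc(OC)c(OC)c1OC)c1cccc2ccccc12`) has been tested in a functional assay on MDA-MB-231 cells (Homo sapiens) for inhibition, read by sulforhodamine B assay, with a stated time of 48 h; a lower number here means a stronger inhibitor, a higher number a weaker inhibitor. In this assay compound 1 gives > 20000 nM, which is a limit and not a number. A second compound, compound 2 (`COc1ccc(C(c2ccc(OCCO)cc2)c2cccc3ccccc23)c(OC)c1OC`), gives > 20000 nM, which is also a limit. The whole record so far is therefore (the limit of > 20000 nM in this assay, at which 2 of the 2 values shown sit), so compound 1 offers no measured potency to start from.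

Compound 3 (`CCOC(=O)C(C)C(O)(c1ccc(OC)c(OC)c1OC)c1cccc2ccccc12`) keeps the core of compound 1 and changes one group: 1-(ethoxycarbonyl)ethyl in place of allyl on a saturated chain carbon bound to two aromatic carbons and an oxygen on a saturated carbon. The counted difference is 1-(ethoxycarbonyl)ethyl in place of allyl on a saturated chain carbon bound to two aromatic carbons and an oxygen on a saturated carbon. Within the data shown here, no measured pair of compounds shows what a change of this kind does in this assay. The expectation therefore rests on compound 1, whose reading is the limit > 20000 nM. The expected size of the step that the limit leaves unreadable from compound 1 to compound 3 is none beyond the scatter, in either direction. For compound 3 the estimate is 25000 nM, with an expected range from 10000 nM to 50000 nM, and another limit rather than a number is the likeliest report.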

Compound 3, half-maximal inhibitory concentration: > 20000 nM
Compound 3 ended at the assay's limit; the forecaster's own chance of this, stated with the estimate: 75%; the middle value lies beyond the limit too.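

In this assay compound 3 gives > 20000 nM, which is a limit and not a number. Among these compounds, compound 1 also sits at a limit, so no step from compound 1 to compound 3 can be read. The compounds shown leave open what any change in structure does to potency, as every reading stands at the same limit: the limit of > 20000 nM in this assay, at which 3 of the 3 values shown sit.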